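The compounds below may be only part of what the source reports. "The series", "measured", "known", "first", "only" and "open" are said of these compounds alone.

Series notes on a functional assay on CHO cells for antagonist activity at prostaglandin E2 receptor EP3 subtype (Homo sapiens), read by cAMP accumulation; a higher number here means a weaker inhibitor, a lower number a stronger inhibitor. Of the compounds shown here, two carry numbers so far. Compound 1 `CCn1ncc2c(F)cc(-c3ccc(C(CC)(CC)c4nnc(C)[nH]4)c(=O)[nH]3)cc21` gives 90 nM in this assay. Compound 2 `CC(C)C(c1ccc(-c2ccc3cccc(F)c3c2)[nH]c1=O)N1CCCCC1=O` gives 40 nM in this assay, the lowest of the two numbers; compound 1 is its nearest neighbour, and the gap between compound 1 and compound 2 lies beyond the usual scatter, so compound 2 reads as the stronger inhibitor of the pair. Among the measured compounds shown here, the two differ in several places at once, so no single-change step connects them and nothing more than the two numbers can be read from that comparison.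

Compound 3 `Cc1c[nH]c(C(c2ccc(-c3ccc4cccc(F)c4c3)[nH]c2=O)C(C)C)n1` has not yet been measured in this assay. It differs from compound 2 in one place: 4-methyl-1H-imidazol-2-yl in place of 2-oxopiperidin-1-yl on a saturated chain carbon bound to an aromatic carbon and a saturated chain carbon The shared core of compound 2 is kept. For the measured compounds named here, no single-change step exists to anchor the size of such an exchange. A swap of a six-membered non-aromatic ring for a five-membered aromatic ring on the same saturated chain carbon is expected to move the number little; the step of a 1.5-fold higher number from compound 2 to compound 3 (0.18 log units; within the scatter) is expected to stay within the scatter, leaning if anything towards a higher number. Compound 3 is therefore estimated at 60 nM in this assay, with a range from 20 nM to 200 nM.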

Compound 3, half-maximal inhibitory concentration: 36 nM
Compound 3: middle estimate off by 1.7-fold (0.22 log units), on the high side; the range from low to high includes it.
By their numbers in this assay, from the lowest: compounds 3 and 2 (each within the scatter of the next); then compound 1.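

In this assay the series now has its first single-change step, on a saturated chain carbon bound to an aromatic carbon and a saturated chain carbon: 4-methyl-1H-imidazol-2-yl in place of 2-oxopiperidin-1-yl gives a 1.1-fold lower number from compound 2 to compound 3 (0.05 log units; within the scatter) and so leaves compound 2 and compound 3 within the scatter of each other. For this pair, the number therefore does not separate one six-membered non-aromatic ring with 1 hetero atom and 0 hydrogen-bond donors from one five-membered aromatic ring with 2 hetero atoms and 1 hydrogen-bond donor. The exchange also removes the double bond outside aromatic rings and still shows no step beyond the scatter, although this single pair sets no pattern for the position.

The compounds shown leave open what the methyl group on the imidazole contributes, and whether a carboxylic acid or a primary amine on the same saturated chain carbon would read like compound 2 and compound 3. Whether this exchange reads the same on another core also stays open, and nothing at hand explains the result.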